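Swapping a Pyrazole for an Imidazole on the Side Arm

This account rests on a few compounds, and the source may have more. Where it says the series, first, only, none or still open, it means among the compounds named here.

Compound 1 `Cc1ccc(CN2CCN(c3cccc4[nH]c(-c5ccc(C(C)(C)C)cc5)nc34)CC2)o1`: 705 nM
Compound 2 `CCc1cc(CN2CCN(c3cccc4[nH]c(-c5ccc(C(C)(C)C)cc5)nc34)CC2)nn1C`: 43 nM

Both compounds were tested in an assay on isolated protein for displacement of a labelled ligand from Gonadotropin-releasing hormone receptor (Homo sapiens); a higher number here means a weaker inhibitor, a lower number a stronger inhibitor. Compound 2 gives the lower of the two numbers, with compound 1 far higher a 16-fold lower number from compound 1 to compound 2 (1.21 log units; beyond the scatter). Compound 3 `CCCCc1nc(CN2CCN(c3cccc4[nH]c(-c5ccc(C(C)(C)C)cc5)nc34)CC2)cn1C` carries a different five-membered ring on the same arm: 2-butyl-1-methyl-1H-imidazol-4-yl in place of 5-ethyl-1-methyl-1H-pyrazol-3-yl on a saturated chain carbon bound to an amine nitrogen in a ring. Among the measured compounds shown here, the only measured step, from a furan to a pyrazole, does not cover this pyrazole-to-imidazole change, so no clear direction can be drawn from it. Compound 3 is therefore expected near compound 2, a 1.0-fold higher number from compound 2 to compound 3 (0.02 log units; within the scatter), estimated at 45 nM within 10 nM to 200 nM.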

Compound 3, half-maximal inhibitory concentration: 26 nM
Estimate against measurement, compound 3: 1.7-fold (0.24 log units) above, and the stated range covers the measured number.
By their numbers in this assay, from the lowest: compounds 3 and 2 (each within the scatter of the next); then compound 1.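

The side arm accepts the larger 2-butyl-1-methyl-1H-imidazol-4-yl group, with 10 heavy atoms against 8, without a change beyond the scatter: a 1.7-fold lower number from compound 2 to compound 3 (0.22 log units; within the scatter), and the distance from the furan stays large, with a 27-fold lower number from compound 1 to compound 3 (1.43 log units; beyond the scatter). Nothing here explains these numbers.

Compound 3 differs from compound 2 in both its ring and its alkyl chain, so the effect of each remains unseparated. Also open, from the compounds shown here alone, is how this arm would respond to a carboxylic acid or a primary amine at the end of the chain.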